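The compounds below may be only part of what the source reports. "The series", "measured", "known", "first", "only" and "open" are said of these compounds alone.

In a functional assay on HCT-116 cells (Homo sapiens) for antiproliferative activity, read by CCK-8 assay, with a stated time of 48 h (on this read-out lower numbers stand for stronger inhibition and higher numbers for weaker inhibition), three compounds that share a core have been measured so far. Compound 1 (`O=C(CCCCC(=O)NCCNc1nonc1/C(=N/O)Nc1ccc(F)c(Br)c1)NO`) gives 85400 nM, the highest number of the three and so the weakest inhibition. Compound 2 (`O=C(CCCCCC(=O)NCCNc1nonc1/C(=N/O)Nc1ccc(F)c(Br)c1)NO`) gives 17500 nM, and compound 3 (`Nc1ccccc1NC(=O)c1ccc(C(=O)NCCNc2nonc2/C(=N/O)Nc2ccc(F)c(Br)c2)s1`) gives 7120 nM. Compound 3 carries a different end group rather than a chain of another length, so it offers little guidance here.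

The open question is compound 4 (`O=C(CCCC(=O)NCCNc1nonc1/C(=N/O)Nc1ccc(F)c(Br)c1)NO`), which differs from compound 1 as follows: hydroxycarbamoyl in place of (hydroxycarbamoyl)methyl on a saturated chain carbon, three bonds along the chain from a carbonyl carbon. Put simply, hydroxycarbamoyl stands in place of (hydroxycarbamoyl)methyl, which shortens the chain.

Among the compounds with values here, only one measured step bears on this change: a 4.9-fold lower number from compound 1 to compound 2 (0.69 log units; beyond the scatter). That step lengthens the chain, whereas compound 4 shortens it, so the same trend run backwards points to a higher number. A single step is thin evidence, and nothing shows that each change in chain length counts equally, so a somewhat smaller move is expected. The expected step is a 2.3-fold higher number from compound 1 to compound 4 (0.37 log units; beyond the scatter). For compound 4 the estimated value is 200000 nM, with an expected range from 80000 nM to 450000 nM.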

Compound 4, half-maximal inhibitory concentration: 80200 nM
Compound 4: middle estimate off by 2.5-fold (0.40 log units), on the high side, within the range that was stated.
By their numbers in this assay, from the lowest: compound 3; then compound 2; then compounds 4 and 1 (each within the scatter of the next).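

In this assay, hydroxycarbamoyl in place of (hydroxycarbamoyl)methyl gives a 1.1-fold lower number from compound 1 to compound 4 (0.03 log units; within the scatter), so compound 1 and compound 4 cannot be told apart, and this shortening of the chain leaves no readable mark at this position. The comparison with the longer chain looks different: hydroxycarbamoyl in place of 2-(hydroxycarbamoyl)ethyl gives a 4.6-fold higher number from compound 2 to compound 4 (0.66 log units; beyond the scatter), so among these three compounds, chain length does not act in even steps, and only compound 2 stands clear of the other two. Nothing in the data shown explains why the two shorter chains match while the longest one differs.

As far as these compounds go, it remains open whether a chain longer than that of compound 2 would bring the number down further, or whether compound 2 already lies near the best length for this series. From the compounds shown here alone, it is equally open whether a chain shorter than that of compound 4 would stay level with compound 4, and whether a carboxylic acid in place of hydroxycarbamoyl would keep any of the activity seen at these chain lengths.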